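This account rests on a few compounds, and the source may have more. Where it says the series, first, only, none or still open, it means among the compounds named here.

Measured so far in a functional assay on CFPAC-1 cells (Homo sapiens) for inhibition, read by MTT assay, with a stated time of 72 h; on this read-out higher numbers stand for weaker inhibition and lower numbers for stronger inhibition:
- compound 1 `CC(O)c1cn(Cc2cc(=O)oc3cc(O)ccc23)nn1`: > 100000 nM, a limit of the assay.
- compound 2 `CC(C)(C)c1cn(Cc2cc(=O)oc3cc(O)ccc23)nn1`: > 100000 nM, a limit of the assay.

Compound 2 stands at the limit of this assay; its value is a limit and not a number. Among the compounds with values here, the one measured step, tert-butyl in place of 1-hydroxyethyl on an aromatic carbon, is a step that the two limits leave unreadable from compound 1 to compound 2, so it tells nothing about size or direction, and the limit of > 100000 nM in this assay, at which 2 of the 2 values shown sit, sums up what the two values show.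

Compound 3 `O=c1cc(Cn2cc(-c3ccc(Br)cc3)nn2)c2ccc(O)cc2o1` differs from compound 2 by 4-bromophenyl in place of tert-butyl on an aromatic carbon. Within the data shown here, no measured step involves a 4-bromophenyl or any aromatic group at this position, so there is no step whose size could be carried over; the only bearing evidence is that compound 2 sits at the limit.

Against that background compound 3 is expected to remain near the limit in this assay, with the estimated step of an at least 1.2-fold lower number from compound 2 to compound 3 (0.09 log units; that floor lies within the scatter) carrying no measured support in either direction. The estimate for compound 3 is 80000 nM, within 20000 nM to 200000 nM.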

Compound 3, half-maximal inhibitory concentration: 52900 nM
Compound 3: middle estimate off by 1.5-fold (0.18 log units), on the high side; low and high end bracket the measured number.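

In this assay, within the data shown here, compound 3 gives 52900 nM, the only value at this position so far that is a number and not a limit. As far as these compounds go, the change to 4-bromophenyl reads as an at least 1.8-fold lower number from compound 2 to compound 3 (0.27 log units; that floor lies within the scatter), and the same group in place of 1-hydroxyethyl reads as an at least 1.8-fold lower number from compound 1 to compound 3 (0.27 log units; that floor lies within the scatter); both are floors, so the full size of each step stays unknown. The step between the two groups without a ring cannot be read, so the 4-bromophenyl compound alone gives this position a number: the limit of > 100000 nM in this assay, at which 2 of the 3 values shown sit.

From the compounds shown here alone, whether the step rests on the bromine or on the phenyl ring itself stays open, as does how a plain phenyl or a 4-aminophenyl would read at this place. Also open, going by these compounds, is how a carboxylic acid or a longer chain on the same carbon would read.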